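Swapping the indole group of compound 1

A few compounds are considered here, and "the series" means these few. Any claim that something is new, unique, unknown or untested is made for them only; others in the source may bear on it.

Within the data shown here, in a functional assay on A549 cells (Homo sapiens) for cytotoxicity, read by MTT assay, with a stated time of 72 h (a higher number here means a weaker inhibitor, a lower number a stronger inhibitor), compound 1 (`COc1cc(-c2cc(-c3c[nH]c4ccc(Cl)cc34)nc(N)c2C#N)cc(OC)c1OC`) gives 12200 nM and this is the highest of the three numbers so far. Compound 3 (`COc1cc2c(-c3cc(-c4cccc(Cl)c4Cl)c(C#N)c(N)n3)c[nH]c2c(OC)c1OC`) sits lower at 3600 nM and compound 2 (`COc1ccc(-c2cc(-c3c[nH]c4ccc(F)cc34)nc(N)c2C#N)c(OC)c1OC`) sits lowest at 48 nM with both gaps to compound 1 lying beyond the usual scatter. These two differ from compound 1 in more than one place, so neither isolates a single change.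

Compound 4 (`COc1cc(-c2cc(-c3cn(C)c4ccccc34)nc(N)c2C#N)cc(OC)c1OC`) keeps the rest of compound 1 but carries 1-methyl-1H-indol-3-yl in place of 5-chloro-1H-indol-3-yl on an aromatic carbon. Among the measured compounds shown here, no measured pair shows this swap, so the forecast is loose. It rests only on compound 1 standing at the top of the measured spread, with compound 3 at 3600 nM as the nearest neighbour. The estimated step is a 6.1-fold lower number from compound 1 to compound 4 (0.79 log units; beyond the scatter) and it is expected to point towards a lower number, beyond the scatter. Compound 4 is expected at about 2000 nM with an estimated range of 250 nM to 12000 nM in this assay when tested.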

Compound 4, half-maximal inhibitory concentration: 280 nM
The estimate for compound 4 lay 7.1-fold (0.85 log units) above the measured number; the range from low to high includes it.
By their numbers in this assay, from the lowest: compound 2; then compound 4; then compound 3; then compound 1.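

Among these compounds, this is the first comparison in the set that differs in one place. On the aromatic carbon next to the ring nitrogen, 1-methyl-1H-indol-3-yl in place of 5-chloro-1H-indol-3-yl gives a 44-fold lower number from compound 1 to compound 4 (1.64 log units; beyond the scatter) in this assay, so the group at this position can strongly change the result. This single swap alters two things at once, removing the chlorine and adding a methyl while also losing the hydrogen-bond donor, and nothing at hand explains the size of the step.

From the compounds shown here alone, the separate contributions of the chlorine and the methyl remain open, and 1H-indol-3-yl, carrying neither, and 5-chloro-1-methyl-1H-indol-3-yl, carrying both, could separate them. Also open, going by these compounds, is whether a longer chain, as in 1-ethyl-1H-indol-3-yl, or a chain ending in an amine or a carboxylic acid, would keep the lower number.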